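The source may hold more compounds than are shown below. What is called first, only, known or untested is meant among the compounds shown, and "the series" means these compounds.

Of the compounds shown here, three have been tested in a functional assay on SMMC-7721 cells (Homo sapiens) for cytotoxicity, read by MTT assay, with a stated time of 72 h; a higher number here means a weaker inhibitor, a lower number a stronger inhibitor. Compound 1, `CCSC(=S)N[C@H]1CCOC1=O`, gave only a limit of the assay, > 128000 nM. Compound 2, `CCCCCCCCSC(=S)N[C@H]1CCOC1=O`, differs from it by a hexyl on the chain and gives 65100 nM. Between them, an at least 1.9-fold lower number from compound 1 to compound 2 (0.29 log units; that floor lies within the scatter), and that floor sits inside the usual scatter of repeated runs. Within the data shown here, compound 3, `O=C(CCl)Nc1ccc(C(=O)/C=C/c2ccc(Cl)cc2)cc1`, is built on a different core and gives 8160 nM, the lowest of the numbers so far; its nearest neighbour is compound 2, and the gap between those two values lies beyond the scatter. Compound 4, `Cc1ccc(/C=C/C(=O)c2ccc(NC(=O)CCl)cc2)cc1`, is still to be measured. Its difference from compound 3 is methyl in place of chloro on an aromatic carbon. Among the measured compounds shown here, no measured step speaks to this kind of change: the single step known, from compound 1 to compound 2, concerns a chain on another core, and no swap of chloro for methyl on a ring has been measured. In this assay the expected step, a 1.0-fold higher number from compound 3 to compound 4 (0.02 log units; within the scatter), is therefore no change beyond the scatter. Compound 4 is estimated to give about 8500 nM, within a range of 3000 nM to 25000 nM.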

Compound 4, half-maximal inhibitory concentration: 22900 nM
Compound 4: the middle estimate sits 2.7-fold (0.43 log units) below what was measured; the range from low to high includes it.
By their numbers in this assay, from the lowest: compound 3; then compound 4; then compound 2. At a limit, above all of these: compound 1.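

In this assay, the swap from 4-chlorophenyl to 4-methylphenyl on the shared core gives a 2.8-fold higher number from compound 3 to compound 4 (0.45 log units; beyond the scatter). Among these compounds, the earlier compounds spoke only of a chain on the core of compound 1, so this is the only direct evidence on the aromatic ring: exchanging one small group for another on this carbon, para to a large group, is enough to move the number beyond the scatter, and in this pair the chloro compound, compound 3, is the stronger inhibitor. Nothing measured here bears on why these two groups give different numbers.

From the compounds shown here alone, with only chloro and methyl compared at this place, it remains open how a fluoro, a methoxy or an amine on the same ring carbon would behave, and where each would fall relative to compound 3 and compound 4. Going by these compounds, whether the same swap would give a step of similar size on a different core also remains open.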